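This account rests on a few compounds, and the source may have more. Where it says the series, first, only, none or still open, it means among the compounds named here.

Working notes on the series, read in a functional assay on NCI-H1581 cells (Homo sapiens) for antiproliferative activity, read by CCK-8 assay, with a stated time of 72 h; a lower number here means a stronger inhibitor, a higher number a weaker inhibitor. Compound 1 `COc1cc(OC)c(Cl)c(-c2ccc3c(NC(=O)c4ccc(N5CCN(C(C)C)CC5)cc4)n[nH]c3n2)c1Cl` gives 1.4 nM, compound 2 `COc1cc(OC)c(Cl)c(-c2ccc3c(NC(=O)c4ccc(N5CCN(C6CCC6)CC5)cc4)n[nH]c3n2)c1Cl` gives 2.3 nM, and compound 3 `COc1cc(OC)c(Cl)c(-c2ccc3c(NC(=O)c4ccc(N5CCN(S(C)(=O)=O)CC5)cc4)n[nH]c3n2)c1Cl` gives 245 nM, the highest of the three numbers. Compound 4 `COc1cc(OC)c(Cl)c(-c2ccc3c(NC(=O)c4ccc(N5CCNCC5)cc4)n[nH]c3n2)c1Cl` differs from compound 3 by hydrogen in place of methylsulfonyl on an amine nitrogen in a ring, with hydrogen in place of methylsulfonyl on an amine nitrogen in a ring. Two large steps bear on this: a 180-fold higher number from compound 1 to compound 3 (2.24 log units; beyond the scatter) and a 110-fold higher number from compound 2 to compound 3 (2.03 log units; beyond the scatter), each with methylsulfonyl entering in place of isopropyl or cyclobutyl. The exchange of those two groups, a 1.6-fold higher number from compound 1 to compound 2 (0.22 log units; within the scatter), stays within the scatter. Within the data shown here, no compound with hydrogen at this place has a measured value, so the recovery may be incomplete. The expected change in this assay is a 41-fold lower number from compound 3 to compound 4 (1.61 log units; beyond the scatter), a large step to a lower number. For compound 4 the estimated value is 6 nM, with an expected range of 1.5 nM to 30 nM.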

Compound 4, half-maximal inhibitory concentration: 1.4 nM
Beside the measured number, compound 4's estimate is 4.3-fold (0.63 log units) above it; the measured number lies below the stated range.
By their numbers in this assay, from the lowest: compounds 1, 4 and 2 (each within the scatter of the next); then compound 3.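

Hydrogen in place of methylsulfonyl gives a 180-fold lower number from compound 3 to compound 4 (2.24 log units; beyond the scatter), so the large loss seen with 4-(methylsulfonyl)piperazin-1-yl does not appear with the plain piperazin-1-yl. The isopropyl and cyclobutyl groups are not needed at this amine nitrogen: the steps read no change at the digits printed from compound 1 to compound 4 (within the scatter) and a 1.6-fold lower number from compound 2 to compound 4 (0.22 log units; within the scatter), leaving methylsulfonyl alone apart among the four compounds. Nothing measured here accounts for the effect of methylsulfonyl.

Going by these compounds, whether an acetyl group on this nitrogen tracks methylsulfonyl stays open. So does whether a longer chain, such as hydroxyethyl, tracks isopropyl and cyclobutyl.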